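Adding a methyl to the 1-hydroxyethyl group of compound 3

The source may report more compounds than this note shows. Statements on the series, on what has been measured and on what is new or still open speak of the compounds shown alone.

Compound 1 (`CC[C@@H](Nc1nc(NCc2ccccn2)c2ncn(C(C)C)c2n1)C(C)(C)O`): > 50000 nM (a limit of the assay)
Compound 2 (`CCC(O)[C@@H](CC)Nc1nc(NCc2ccccn2)c2ncn(C(C)C)c2n1`): 29000 nM
Compound 3 (`CC[C@H](Nc1nc(NCc2ccccn2)c2ncn(C(C)C)c2n1)C(C)O`): 10000 nM

Of the two true numbers in a functional assay on HCT-116 cells (Homo sapiens) for inhibition, read by sulforhodamine B assay, with a stated time of 96 h (a lower number here means a stronger inhibitor of growth, a higher number a weaker inhibitor of growth), the lower belongs to compound 3. The gap is a 2.9-fold lower number from compound 2 to compound 3 (0.46 log units; beyond the scatter).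

The next structure is compound 4 (`CC[C@H](Nc1nc(NCc2ccccn2)c2ncn(C(C)C)c2n1)C(C)(C)O`). It differs from compound 3 by methyl in place of hydrogen on a saturated chain carbon bound to an oxygen on a saturated carbon and two saturated chain carbons, which turns 1-hydroxyethyl into 1-hydroxy-1-methylethyl.

The closest evidence is the same group change run in reverse (an at least 5.0-fold lower number from compound 1 to compound 3 (0.69 log units; beyond the scatter)). That size is only a floor, since the value of compound 1 is a limit. Compound 1 and compound 3 are also drawn with opposite handedness, so the match to the present change is imperfect. A smaller step in the same direction therefore seems likely, towards weaker growth inhibition. The expected step in this assay is estimated as a 2.0-fold higher number from compound 3 to compound 4 (0.30 log units; within the scatter).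

The estimated value for compound 4 is 20000 nM (expected range 7000 nM to 50000 nM).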

Compound 4, concentration for 50% growth inhibition: 32000 nM
Compound 4: the middle estimate sits 1.6-fold (0.20 log units) below what was measured; measured number inside the range.
By their numbers in this assay, from the lowest: compound 3; then compounds 2 and 4 (each within the scatter of the next). At a limit, above all of these: compound 1.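

In this assay, turning 1-hydroxyethyl into 1-hydroxy-1-methylethyl gives a 3.2-fold higher number from compound 3 to compound 4 (0.51 log units; beyond the scatter). This sizes the methyl change at a single drawn configuration, which the earlier comparison of the same groups could not do, as it also crossed handedness and ended at a limit. The 1-(1-hydroxy-1-methylethyl)propyl and 1-ethyl-2-hydroxybutyl groups cannot be told apart in this assay, with a 1.1-fold higher number from compound 2 to compound 4 (0.04 log units; within the scatter).

Compound 1 stands at a limit, so the comparison of the two configurations reads only as an at least 1.5-fold lower number from compound 1 to compound 4 (0.19 log units; that floor lies within the scatter), and the size of the configuration effect stays open: the limit of > 50000 nM in this assay, at which 1 of the 4 values shown sits.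

Also open, on these data alone, is how this position responds to an ethyl in place of the added methyl, or to an amine in place of the hydroxyl.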